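Urea to amide on the anilide of compound 2

The source may hold more compounds than are shown below. What is called first, only, known or untested is meant among the compounds shown, and "the series" means these compounds.

The two measured compounds share a core and differ only at one oxygen: compound 1 `O=C(Nc1cccc(-n2cc(-c3ccncc3)c(-c3cc(O)cc(Cl)c3)n2)c1)Nc1ccc(Cl)c(Cl)c1` carries a hydroxyl there, compound 2 `COc1cc(Cl)cc(-c2nn(-c3cccc(NC(=O)Nc4ccc(Cl)c(Cl)c4)c3)cc2-c2ccncc2)c1` a methoxy. In a functional assay on CAKI-1 cells (Homo sapiens) for inhibition, read by sulforhodamine B assay, with a stated time of 48 h, tested at 1 uM (on this read-out lower numbers stand for a stronger effect and higher numbers for a weaker effect at the one concentration tested), compound 1 gives 54%, and compound 2 gives 79%. The step of a number 25 percentage points higher from compound 1 to compound 2 (beyond the scatter) is the only one on record and puts compound 2 at the higher, weaker end of the two numbers.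

Compound 3 `COc1cc(Cl)cc(-c2nn(-c3cccc(NC(=O)c4cccc(C(F)(F)F)c4)c3)cc2-c2ccncc2)c1` keeps the methoxy of compound 2 and changes a different part: 3-(trifluoromethyl)phenyl in place of (3,4-dichlorophenyl)amino on a carbonyl carbon. Within the data shown here, no measured step touches the carbonyl side of the molecule, so the change from compound 2 to compound 3 has no direct precedent here; the one known step concerns the oxygen on the aromatic ring and says nothing about the urea being turned into an amide.

With no guidance, compound 3 is expected to stay near compound 2, with a wide range; the estimated step of a number 1 percentage points lower from compound 2 to compound 3 (within the scatter) is taken as within the scatter. The estimate for compound 3 in this assay is 78%, between 52% and 100%.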

Compound 3, a percentage reported as activity, at one concentration (the size of the read-out at that concentration, not a potency): 90%
The estimate for compound 3 lay 12 percentage points below the measured number; the measured number falls inside the stated range.
By their numbers in this assay, from the lowest: compound 1; then compound 2; then compound 3.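

Replacing (3,4-dichlorophenyl)amino with 3-(trifluoromethyl)phenyl on the carbonyl carbon turns the urea into an amide and gives, in this assay, a number 11 percentage points higher from compound 2 to compound 3 (beyond the scatter). This shows that the carbonyl side of the molecule, which the earlier step did not touch, also moves the read-out, and here the movement is toward the weaker end. The change removes the hydrogen-bond donor counted in the leaving group and replaces the dichlorophenyl ring with a trifluoromethyl-bearing one in a single step, and no measurement offered here explains why the number rises.

The compounds shown leave open whether the step follows from the loss of the urea nitrogen or from the change of ring substituents, a question that (3-(trifluoromethyl)phenyl)amino or 3,4-dichlorophenyl on the same carbonyl carbon would separate. They also leave open whether this step would have the same size with the hydroxyl of compound 1 in place of the methoxy, and how an unsubstituted phenyl or a carboxylic acid on that ring would read.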